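This account rests on a few compounds, and the source may have more. Where it says the series, first, only, none or still open, it means among the compounds named here.

Working notes on the hydroxamic acid series.

Three compounds have numbers in an assay on Sf9 cells for inhibition of protein deacetylase HDAC6 (Homo sapiens), read by mobility shift assay; a lower number here means a stronger inhibitor, a higher number a weaker inhibitor. Compound 1 `O=C(NO)c1ccc(N(Cc2ccc(C(F)(F)F)cc2)C(=O)CN(Cc2ccccc2C(F)(F)F)S(=O)(=O)c2ccc(F)c(F)c2)cc1` gives 188 nM. Compound 2 `O=C(NO)c1ccc(N(Cc2ccc(C(F)(F)F)cc2)C(=O)CN(Cc2ccccc2C(F)(F)F)S(=O)(=O)c2ccc(F)cc2)cc1` gives 93 nM. Compound 3 `CC(C)(C)c1ccc(CN(C(=O)CN(Cc2c(F)c(F)c(F)c(F)c2F)S(=O)(=O)c2ccc(F)cc2)c2ccc(C(=O)NO)cc2)cc1` gives 190 nM. Compound 3 carries the highest number of the three; its gap to compound 1 lies within the scatter, while compound 2 sits beyond the scatter below it. Within the data shown here, the only single-point step measured so far is a 2.0-fold lower number from compound 1 to compound 2 (0.31 log units; beyond the scatter), on the sulfonyl-bearing ring.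

Compound 4 `O=C(NO)c1ccc(N(Cc2ccc(C(F)(F)F)cc2)C(=O)CN(Cc2c(F)c(F)c(F)c(F)c2F)S(=O)(=O)c2ccc(F)cc2)cc1` is not yet measured. The change from compound 3 is trifluoromethyl in place of tert-butyl on an aromatic carbon. Among the measured compounds shown here, compound 4 also shares its sulfonyl-bearing ring with compound 2, and that pair differs only at the benzyl group on the sulfonamide nitrogen, for which no step is measured; their two values will simply be compared once known.

For the measured compounds named here, no measured step bears on an exchange of tert-butyl for trifluoromethyl, so the expectation rests on the groups themselves: both enter as four heavy atoms without donors, acceptors or charge. Compound 4 is therefore expected to give 150 nM, between 60 nM and 400 nM, the expected step being a 1.3-fold lower number from compound 3 to compound 4 (0.10 log units; within the scatter), which would not be beyond the scatter.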

Compound 4, half-maximal inhibitory concentration: 86 nM
The estimate for compound 4 lay 1.7-fold (0.24 log units) above the measured number, and the stated range covers the measured number.
By their numbers in this assay, from the lowest: compounds 4 and 2 (each within the scatter of the next); then compounds 1 and 3 (each within the scatter of the next).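

In this assay, trifluoromethyl in place of tert-butyl on the aromatic carbon of the benzyl group gives a 2.2-fold lower number from compound 3 to compound 4 (0.34 log units; beyond the scatter), the only step at this position among the compounds shown, and it lies beyond the scatter. With 4-(trifluoromethyl)benzyl held constant, 2,3,4,5,6-pentafluorophenyl in place of 2-(trifluoromethyl)phenyl gives a 1.1-fold lower number from compound 2 to compound 4 (0.03 log units; within the scatter), so this exchange on the sulfonamide side does not separate the two compounds. Nothing at hand gives a reason for either result.

On these data alone, the tert-butyl exchange is read on a single pair, so whether it carries over to compounds with the 2-(trifluoromethyl)phenyl group remains open. Also open, as far as these compounds go, is how a carboxylic acid or an amine on that same aromatic carbon would read in this assay.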